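Compound 3 to compound 4: carboxymethyl on the amide nitrogen

The source may report more compounds than this note shows. Statements on the series, on what has been measured and on what is new or still open speak of the compounds shown alone.

In a functional assay on K562 cells (Homo sapiens) for antiproliferative activity, read by MTT assay, with a stated time of 48 h (a higher number here means a weaker inhibitor, a lower number a stronger inhibitor), compound 3 (`CC[C@@H](C)[C@H](NC(=O)c1ccc(Oc2nc3ccccc3nc2NC(C)(C)C)cc1)C(=O)OC`) gives 38700 nM. Compound 2 (`COC(=O)[C@H](C)NC(=O)c1ccc(Oc2nc3ccccc3nc2NC(C)(C)C)cc1`) gives 42200 nM, within the scatter of the compound 3 value. Compound 1 (`COC(=O)CNC(=O)c1ccc(Oc2nc3ccccc3nc2NC(C)(C)C)cc1`) gives > 50000 nM, which is a limit of the assay and not a number.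

Compound 4 (`CC(C)(C)Nc1nc2ccccc2nc1Oc1ccc(C(=O)NCC(=O)O)cc1`) follows from compound 3 by one change: carboxymethyl in place of 1-(methoxycarbonyl)-2-methylbutyl on an amide-type nitrogen. In words, carboxymethyl stands in place of 1-(methoxycarbonyl)-2-methylbutyl on an amide-type nitrogen.

For the measured compounds named here, three measured steps bear on the chain part of this change: an at least 1.1-fold lower number from compound 1 to compound 2 (0.07 log units; that floor lies within the scatter), an at least 1.2-fold lower number from compound 1 to compound 3 (0.11 log units; that floor lies within the scatter) and a 1.1-fold lower number from compound 2 to compound 3 (0.04 log units; within the scatter). All three lie within the scatter, and the first two are floors only. Going by the values given here, no measured compound carries the carboxymethyl group, so that part of the change has no measured step.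

Compound 4 has no substituent on the chain carbon, like compound 1, whose > 50000 nM is a limit. A step to a higher number, meaning weaker inhibition, is therefore expected in this assay, and the assay may well report only a limit. The expected size is a 1.8-fold higher number from compound 3 to compound 4 (0.26 log units; within the scatter). The estimated value for compound 4 is 70000 nM, with an expected range of 40000 nM to 150000 nM.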

Compound 4, half-maximal inhibitory concentration: > 50000 nM
Compound 4: only a limit was reported (the forecaster's own chance of this, stated with the estimate: 75%); the middle value is on the limit's open side.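

In this assay compound 4 gives > 50000 nM, which is a limit of the assay and not a number. Carboxymethyl on the amide-type nitrogen gives an at least 1.2-fold higher number from compound 3 to compound 4 (0.11 log units; that floor lies within the scatter) and an at least 1.1-fold higher number from compound 2 to compound 4 (0.07 log units; that floor lies within the scatter); both are floors that lie within the scatter, so the true size of the change from the substituted methyl esters stays unknown. Compound 1 and compound 4 differ only by hydrogen in place of methyl on an oxygen next to a carbonyl group, the first direct comparison of a carboxylic acid with its methyl ester in this series, yet their step cannot be read, because both values are the same limit: the limit of > 50000 nM in this assay, at which 2 of the 4 values shown sit.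

The compounds shown leave open whether the carboxylic acids matching compound 2 and compound 3, which keep the methyl or sec-butyl group on the chain carbon, differ from those esters in this assay. Also open, on these data alone, is whether an amine, a primary amide or a longer chain on the amide-type nitrogen gives a number clearly apart from those of compound 2 and compound 3.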